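Hydroxy to methoxy on the styryl lactone series

This account rests on a few compounds, and the source may have more. Where it says the series, first, only, none or still open, it means among the compounds named here.

Compounds measured so far in a functional assay on U-251 cells (Homo sapiens) for inhibition, read by sulforhodamine B assay, with a stated time of 48 h; a higher number here means a weaker inhibitor of growth, a lower number a stronger inhibitor of growth
Compound 1 `CC1(/C=C/c2ccccc2)C=CC(=O)O1` gives 89800 nM
Compound 2 `COc1ccc(/C=C/C2(C)C=CC(=O)O2)c(OC)c1` gives 62800 nM
Compound 3 `CC1(/C=C/c2ccccc2O)C=CC(=O)O1` gives 70900 nM

Compound 3 at 70900 nM lies within the scatter of both compound 1 and compound 2, so these values set no order. Compound 4 `COc1ccccc1/C=C/C1(C)C=CC(=O)O1` differs from compound 3 by methyl in place of hydrogen on an oxygen on an aromatic ring and carries methyl in place of hydrogen on an oxygen on an aromatic ring, hydroxy to methoxy. For the measured compounds named here, the one measured step that bears on this is hydroxy in place of hydrogen on an aromatic carbon, which gave a 1.3-fold lower number from compound 1 to compound 3 (0.10 log units; within the scatter) and stayed within the scatter. Compound 2 also carries methoxy and gives 62800 nM without a direct step to compound 3. In this assay no change beyond the scatter is therefore expected, and the estimated step is a 1.0-fold lower number from compound 3 to compound 4 (0.02 log units; within the scatter) and nothing more. For compound 4 the estimated value is 68000 nM (expected range 42000 nM to 100000 nM).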

Compound 4, concentration for total growth inhibition: 41100 nM
Estimate against measurement, compound 4: 1.7-fold (0.22 log units) above; measured number outside the range, below it.
By their numbers in this assay, from the lowest: compounds 4, 2, 3 and 1 (each within the scatter of the next, the first and the last beyond it).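

In this assay, methyl in place of hydrogen on the oxygen gives a 1.7-fold lower number from compound 3 to compound 4 (0.24 log units; within the scatter), and hydrogen in place of methoxy on an aromatic carbon gives a 1.5-fold lower number from compound 2 to compound 4 (0.18 log units; within the scatter), so neither step separates the compounds. Adding methoxy gives a 2.2-fold lower number from compound 1 to compound 4 (0.34 log units; beyond the scatter), a modest step and the first in this set to pass beyond the scatter. No evidence here accounts for this result. On these data alone, what remains open is whether a longer chain on that oxygen, such as ethyl, would keep this level. An amine at that place is equally unresolved.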